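Quinoxaline-fused spirooxindole triazoles: antiproliferative inactivity so far

This account rests on a few compounds, and the source may have more. Where it says the series, first, only, none or still open, it means among the compounds named here.

Measured compounds:
compound 1 `N#CC1=C(N)Oc2c(c3nc4ccccc4nc3c3ccccc23)C12C(=O)N(Cc1cnnn1-c1ccc(N)cc1)c1ccccc12` — > 50000 nM
compound 2 `Cc1ccc(-n2nncc2CN2C(=O)C3(C(C#N)=C(N)Oc4c3c3nc5ccccc5nc3c3ccccc43)c3ccccc32)cc1C` — > 50000 nM
compound 3 `COc1ccc(-n2nncc2CN2C(=O)C3(C(C#N)=C(N)Oc4c(N)cc5nc6ccccc6nc5c43)c3ccccc32)cc1` — > 50000 nM

In a functional assay on HepG2 cells (Homo sapiens) for antiproliferative activity, read by MTT assay, with a stated time of 48 h (a lower number here means a stronger inhibitor, a higher number a weaker inhibitor), compound 1 returns only a limit of the assay, > 50000 nM, not a number. Compound 2 likewise returns only a limit, > 50000 nM. Compound 3 also returns only a limit, > 50000 nM; no numeric potency exists for it, and the same holds for the two other values shown. Among the measured compounds shown here, the single one-place step, a step that the two limits leave unreadable from compound 1 to compound 2, is unreadable, as both ends sit at the limit of > 50000 nM in this assay, at which 3 of the 3 values shown sit.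

Compound 4 `N#CC1=C(N)Oc2c(N)cc3nc4ccccc4nc3c2C12C(=O)N(Cc1cnnn1-c1ccc(Cl)cc1[N+](=O)[O-])c1ccccc12` differs from compound 3 by 4-chloro-2-nitrophenyl in place of 4-methoxyphenyl on an aromatic nitrogen. For the measured compounds named here, no measured step touches the group on the aromatic nitrogen with a readable size, so no direction can be drawn from the series; the only guide is that every compound so far, including compound 3 with > 50000 nM, sits at the limit. Compound 4 is therefore expected to give 50000 nM in this assay, between 15000 nM and 200000 nM, most likely again reported only as a limit. The estimated step from compound 3 is a number no higher from compound 3 to compound 4 (the limit leaves the size open), meaning no change beyond the scatter is expected.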

Compound 4, half-maximal inhibitory concentration: > 50000 nM
Compound 4 was reported as a limit (the forecaster's own chance of this, stated with the estimate: 85%); the middle value sits exactly at the limit.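

Compound 4 gives > 50000 nM in this assay, a limit and not a number, so the step from compound 3 to compound 4 cannot be read: the limit of > 50000 nM in this assay, at which 4 of the 4 values shown sit.

The compounds shown leave open whether any group on the aromatic nitrogen gives a numeric potency in this assay.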